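The source may report more compounds than this note shows. Statements on the series, on what has been measured and on what is new or still open speak of the compounds shown alone.

Compound 1 `Nc1ccc(-c2nc3ccc(F)cc3s2)cc1I`: < 10 nM
Compound 2 `Nc1ccc(-c2nc3cc(F)ccc3s2)cc1`: < 10 nM

In a functional assay on MCF7 cells (Breast, Homo sapiens) for inhibition (a lower number here means a stronger inhibitor of growth, a higher number a weaker inhibitor of growth), compound 2 gives < 10 nM, which is a limit and not a number. Compound 1 gives < 10 nM, also a limit. Thus the limit of < 10 nM in this assay, at which 2 of the 2 values shown sit, describes every measured value. Compound 3 `Nc1ccc(-c2nc3cc(F)ccc3s2)cc1Cl` has chloro in place of hydrogen on an aromatic carbon, ortho to an amino group and meta to a large group (chloro in place of hydrogen on an aromatic carbon). Among the measured compounds shown here, no measured step shows the size of this change, so no shift beyond the scatter is expected in this assay. The expected step is a step that the limit leaves unreadable from compound 2 to compound 3. Compound 3 is estimated to give 6 nM, within an expected range of 1 nM to 30 nM.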

Compound 3, concentration for 50% growth inhibition: < 10 nM
Compound 3: a limit, no number; the forecaster's own chance of this, stated with the estimate: 70%; the middle value is on the limit's open side.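

No step can be read from compound 2 to compound 3, because both results are limits and not numbers: the limit of < 10 nM in this assay, at which 3 of the 3 values shown sit. The compounds shown leave open how strongly each one inhibits growth and what chloro in place of hydrogen changes.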